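Removing an ethyl group from a hydrazone amylase inhibitor

The source may report more compounds than this note shows. Statements on the series, on what has been measured and on what is new or still open speak of the compounds shown alone.

Compound 1 `Oc1ccc(/C=N/n2cnnc2)cc1`: 2990 nM
Compound 2 `CCOc1ccc(/C=N/n2cnnc2)cc1OC`: 5240 nM

Of the compounds shown here, two have been tested in an assay for inhibition of Alpha amylase (Homo sapiens), with a stated time of 10 min; on this read-out higher numbers stand for weaker inhibition and lower numbers for stronger inhibition. Compound 1 gives 2990 nM, and compound 2 gives 5240 nM. These two numbers lie within the usual scatter of repeat measurements of each other, so compound 2 does not stand apart from compound 1 on the numbers shown; the two compounds cannot be told apart by this assay.

Compound 3 `COc1cc(/C=N/n2cnnc2)ccc1O` has not yet been measured. It differs from compound 2 in one place: hydrogen in place of ethyl on an oxygen on an aromatic ring. Going by the values given here, since no step between measured compounds is available, the expectation rests on the two values alone, which sit close together despite differing in two groups. A step of no more than the scatter in either direction is expected for the change from compound 2 to compound 3, a 1.5-fold lower number from compound 2 to compound 3 (0.18 log units; within the scatter). Compound 3 is therefore estimated to give 3500 nM in this assay, within a range of 1500 nM to 8000 nM.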

Compound 3, half-maximal inhibitory concentration: 5940 nM
Compound 3: middle estimate off by 1.7-fold (0.23 log units), on the low side, and the stated range covers the measured number.
By their numbers in this assay, from the lowest: compounds 1, 2 and 3 (each within the scatter of the next).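

Taking the ethyl off the oxygen, so that ethoxy becomes hydroxy, gives a 1.1-fold higher number from compound 2 to compound 3 (0.05 log units; within the scatter) in this assay and so makes no difference this assay can detect. Methoxy in place of hydrogen on an aromatic carbon gives a 2.0-fold higher number from compound 1 to compound 3 (0.30 log units; within the scatter) and also stays within the scatter, so each of the two changes can now be read alone, which the first pair of compounds, differing in two places, did not allow. No measurement available here explains why neither change moves the number beyond the scatter.

On these data alone, whether a longer chain on this oxygen, such as butyl or benzyl, would shift the number beyond the scatter remains open. So does the effect of an amine or a carboxylic acid at this place on the ring.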